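The source may hold more compounds than are shown below. What is called first, only, known or untested is meant among the compounds shown, and "the series" means these compounds.

In a functional assay on KB cells (nasopharynx, Homo sapiens) for antiproliferative activity (on this read-out lower numbers stand for stronger inhibition and higher numbers for weaker inhibition), compound 1 (`N#Cc1ccc(S(=O)(=O)Nc2cccc3cc[nH]c23)cc1`) gives 8.5 ug/mL. Compound 2 (`N#Cc1ccc(S(=O)(=O)Nc2cccc3c(C#N)c[nH]c23)cc1`) gives 33 ug/mL. Compound 3 (`N#Cc1ccccc1S(=O)(=O)Nc1cccc2c(C#N)c[nH]c12`) differs from compound 2 only in where one nitrile sits, and compound 3 gives 61 ug/mL. Compound 2 and compound 3 lie within the scatter of each other, so compound 2 belongs with compound 3 at the high end of the three numbers, clearly apart from compound 1.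

The next structure is compound 4 (`N#Cc1c[nH]c2c(NS(=O)(=O)c3ccc(N)cc3)cccc12`), which has amino in place of cyano on an aromatic carbon, para to a large group: amino in place of cyano on an aromatic carbon. Going by the values given here, no measured step covers this exchange. The nearest guide is a 3.9-fold higher number from compound 1 to compound 2 (0.59 log units; beyond the scatter), a modest step in which a cyano was added at a different place in the molecule. It says little about amino, but it is the only measure of what gaining or losing a cyano has done in this small set. A modest step towards a lower number is therefore expected, and its direction is held only loosely. The expected change is a 4.1-fold lower number from compound 2 to compound 4 (0.62 log units; beyond the scatter). For compound 4 the estimated value is 8 ug/mL, with an expected range from 1.5 ug/mL to 40 ug/mL.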

Compound 4, half-maximal inhibitory concentration: 4.4 ug/mL
Compound 4: middle estimate off by 1.8-fold (0.26 log units), on the high side; the range from low to high includes it.
By their numbers in this assay, from the lowest: compounds 4 and 1 (each within the scatter of the next); then compounds 2 and 3 (each within the scatter of the next).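

Going by these compounds alone, the result gives the first reading at this position, on an aromatic carbon of a six-membered aromatic ring of carbon only, para to a large group, where the earlier compounds offered only a nitrile or a nitrile moved elsewhere. In this assay, moving the nitrile left compound 2 at 33 ug/mL and compound 3 at 61 ug/mL within the scatter of each other, whereas exchanging the cyano for an amino gave a 7.5-fold lower number from compound 2 to compound 4 (0.88 log units; beyond the scatter) and so took the number beyond the scatter, showing that the identity of the group on this carbon can alter the read-out even though the position of the nitrile had not. Nothing available here explains why this exchange has that effect.

The compounds shown leave open whether the step belongs to the arrival of the amino group or simply to the departure of the cyano, a question that a plain hydrogen, a hydroxyl or a methylamino group on the same carbon would help settle. They also leave open whether the same exchange would carry over to the core of compound 1, which lacks the second nitrile.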